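Cyano in Place of Fluoro on an Aromatic Carbon

A few compounds are considered here, and "the series" means these few. Any claim that something is new, unique, unknown or untested is made for them only; others in the source may bear on it.

Of the two compounds measured in a physicochemical assay for lipophilicity (on this read-out higher numbers stand for higher lipophilicity and lower numbers for lower lipophilicity), compound 2 (`CCC1C(=O)N(C)c2cnc(-n3ccnc3-c3ccc(F)cc3)nc2N1c1ccc(F)cc1`) stands higher at 3.4, while compound 1 (`CC[C@@H]1C(=O)N(C)c2cnc(-n3ccnc3-c3ccc(F)cc3)nc2N1[C@H]1CCOC1`) gives 2, a gap beyond the usual scatter. Compound 3 (`CCC1C(=O)N(C)c2cnc(-n3ccnc3-c3ccc(F)cc3)nc2N1c1ccc(C#N)cc1`) has not yet been measured. Compound 3 differs from compound 2 by cyano in place of fluoro on an aromatic carbon, with cyano in place of fluoro on an aromatic carbon, para to a large group. Going by the values given here, no measured pair shows this change. In this assay a downward change beyond the scatter is expected, the estimated step being a number 0.60 log units lower from compound 2 to compound 3 (beyond the scatter). Compound 3 is expected at 2.8, with an estimated range of 2.4 to 3.2.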

Compound 3, partition coefficient: 2.7
For compound 3 the middle estimate is 0.10 log units above the measured one; measured number inside the range.
By their numbers in this assay, from the lowest: compound 1; then compound 3; then compound 2.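

The swap of 4-fluorophenyl to 4-cyanophenyl gives the first step read at this position in this assay, a number 0.70 log units lower from compound 2 to compound 3 (beyond the scatter). It shows that this aromatic carbon, para to a large group, is not indifferent to the group it carries, since the change moves the number beyond the scatter. Nothing measured here explains why the number moves with this change. As far as these compounds go, whether an amine, a carboxylic acid or a longer chain at this place would shift the number in the same direction remains open.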